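Swapping the phenyl group of compound 3

A few compounds are considered here, and "the series" means these few. Any claim that something is new, unique, unknown or untested is made for them only; others in the source may bear on it.

Of the compounds shown here, three that share a core have been tested in a functional assay on Caco-2 cells (Homo sapiens) for inhibition, read by MTT assay, with a stated time of 48 h, tested at 10 uM; a higher number here means more inhibition of growth at the concentration tested, a lower number less inhibition of growth. Compound 1 `Cc1cc(=O)c2c(O)c(CN3CCN(C(=O)OC(C)(C)C)CC3)c(O)c([C@H]3CCN(C)C[C@H]3O)c2o1` gives 21%, and compound 2 `Cc1cc(=O)c2c(O)c(CN3CCCC3C(=O)O)c(O)c([C@H]3CCN(C)C[C@H]3O)c2o1` gives 30%. Compound 3 `Cc1oc2c([C@H]3CCN(C)C[C@H]3O)c(O)cc(O)c2c(=O)c1C(O)c1ccc(F)c(Br)c1` gives 6%, the lowest of the three numbers and beyond the usual scatter from both of the others.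

Compound 4 `Cc1oc2c([C@H]3CCN(C)C[C@H]3O)c(O)cc(O)c2c(=O)c1C(O)c1cc(F)cc(F)c1` has not yet been measured. It differs from compound 3 in a single place: 3,5-difluorophenyl in place of 3-bromo-4-fluorophenyl on a saturated chain carbon bound to an aromatic carbon and an oxygen on a saturated carbon. Put simply, 3,5-difluorophenyl stands in place of 3-bromo-4-fluorophenyl on a saturated chain carbon bound to an aromatic carbon and an oxygen on a saturated carbon.

Among the measured compounds shown here, no two tested compounds differ in only one place, so the measurements do not show directly what such a swap does. The closest guide is compound 3 at 6%. A small rise that stays within the scatter is expected, an estimated a number 4 percentage points higher from compound 3 to compound 4 (within the scatter). For compound 4 the estimate is 10%, with an expected range of 0% to 22%.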

Compound 4, percent growth inhibition at one concentration: 10%
Compound 4: the middle estimate sits on the measured number at the digits printed; the range from low to high includes it.
By their numbers in this assay, from the lowest: compounds 3 and 4 (each within the scatter of the next); then compounds 1 and 2 (each within the scatter of the next).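

Among the compounds shown here, this is the first direct reading of a change at this position: in this assay putting 3,5-difluorophenyl in place of 3-bromo-4-fluorophenyl gives a number 4 percentage points higher from compound 3 to compound 4 (within the scatter) and so the two groups cannot be told apart here. For this one pair, bromine can be lost and the fluorine pattern altered on the saturated chain carbon without a change that this assay can separate from the scatter. Nothing measured explains this result.

The compounds shown leave open whether an amine or a carboxylic acid on the phenyl ring, or a longer chain in place of it, would shift the number away from that of compound 3. Compound 3 and compound 4 also both carry the hydroxy group on that carbon, and what it contributes remains an open question.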